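The source may hold more compounds than are shown below. What is called first, only, known or untested is meant among the compounds shown, and "the series" means these compounds.

For the measured compounds named here, in a functional assay on FaDu cells (Homo sapiens) for cytotoxicity, read by MTT assay, with a stated time of 72 h (on this read-out lower numbers stand for higher toxicity in this test and higher numbers for lower toxicity in this test), compound 2 `COc1ccc(NC(=O)C(=O)c2cn(CC3CCO3)c3ccccc23)cn1` gives 686 nM, the only actual number so far. Compound 1 `COc1ccc(NC(=O)C(=O)c2cn(CC(C)(C)OC)c3ccccc23)cn1` gives > 10000 nM, which is a limit. Compound 3 `COc1ccc(NC(=O)C(=O)c2cn(CC3CCCO3)c3ccccc23)cn1` carries oxolan-2-yl in place of oxetan-2-yl on a saturated chain carbon bound to an aromatic nitrogen. Going by the values given here, only one measured step bears on this place, the large at least 14-fold lower number from compound 1 to compound 2 (1.16 log units; beyond the scatter), which exchanged an open-chain group for a ring, whereas here a ring replaces a ring. The expected change is therefore smaller, and a 1.4-fold lower number from compound 2 to compound 3 (0.14 log units; within the scatter) is estimated to stay within the scatter, with its direction uncertain. For compound 3 the expected value is 500 nM, with an estimated range of 120 nM to 2500 nM.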

Compound 3, concentration lethal to 50% of the cells: 31 nM
The estimate for compound 3 lay 16-fold (1.21 log units) above the measured number; the measured number lies below the stated range.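

In this assay, the ring itself matters at this saturated chain carbon bound to an aromatic nitrogen: oxolan-2-yl in place of oxetan-2-yl gives a 22-fold lower number from compound 2 to compound 3 (1.34 log units; beyond the scatter), so a ring-for-ring exchange is not a minor change here. Against the open-chain 1-methoxy-1-methylethyl group, oxolan-2-yl gives an at least 320-fold lower number from compound 1 to compound 3 (2.50 log units; beyond the scatter). That step rests on a limit for compound 1: the limit of > 10000 nM in this assay, at which 1 of the 3 values shown sits.

As far as these compounds go, whether an oxan-2-yl or pyrrolidin-2-yl group would lower the number further stays open. Also open, from the compounds shown here alone, is whether the ring oxygen is needed at all, which a cyclopentyl group would test.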